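Lengthening the Sulfur-Bound Chain of a Chloromethyl Ketone

The source may report more compounds than this note shows. Statements on the series, on what has been measured and on what is new or still open speak of the compounds shown alone.

Compound 1 `CSC[C@H](NC(C)=O)C(=O)CCl` and compound 2 `CCCSC[C@H](NC(C)=O)C(=O)CCl` share one core and differ only in the chain bound to the sulfur. In a functional assay on NALM-6 cells (Homo sapiens) (a higher number here means a weaker inhibitor, a lower number a stronger inhibitor), compound 1 gives 30300 nM, while compound 2 gives 6900 nM. Going by the values given here, the step between them is a 4.4-fold lower number from compound 1 to compound 2 (0.64 log units; beyond the scatter), and so compound 2 stands at the lowest of the two numbers so far, with compound 1 as its only neighbour at the higher value.

Compound 3 `CCCCSC[C@H](NC(C)=O)C(=O)CCl` has not yet been measured. It differs from compound 2 by methyl in place of hydrogen on a saturated chain carbon, three bonds along the chain from a sulfur. Among the compounds with values here, the one measured step that bears on this change is a 4.4-fold lower number from compound 1 to compound 2 (0.64 log units; beyond the scatter), in which the same chain grew by a larger piece. Within the data shown here, with only two compounds, whether further lengthening continues that trend cannot be read from the data, but the direction of the one step is the only guide available. One therefore expects a smaller step in the same direction in this assay, namely a 2.0-fold lower number from compound 2 to compound 3 (0.29 log units; within the scatter). Compound 3 is accordingly estimated at 3500 nM, with a range from 1200 nM to 10000 nM.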

Compound 3, half-maximal inhibitory concentration: 41400 nM
Beside the measured number, compound 3's estimate is 12-fold (1.07 log units) below it, outside the stated range (above it).
By their numbers in this assay, from the lowest: compound 2; then compounds 1 and 3 (each within the scatter of the next).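

In this assay the sulfur-bound chain does not respond steadily to lengthening: the change from propyl to butyl, methyl in place of hydrogen on a saturated chain carbon, three bonds along the chain from a sulfur, gives a 6.0-fold higher number from compound 2 to compound 3 (0.78 log units; beyond the scatter) and so runs against the direction of the earlier step. The butyl chain of compound 3 and the short chain of compound 1 cannot be told apart, as the comparison reads a 1.4-fold higher number from compound 1 to compound 3 (0.14 log units; within the scatter) and stays within the scatter, so among these three compounds only compound 2 stands apart from the other two. Nothing available explains this reversal.

The compounds shown leave open whether the turn is as sharp as it looks here, or whether an ethyl chain or a longer pentyl chain on the sulfur would fit the same picture. They also leave open how a branched isopropyl chain, or a chain ending in an amine or a carboxylic acid, would read in this assay on this sulfur.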